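A few compounds are considered here, and "the series" means these few. Any claim that something is new, unique, unknown or untested is made for them only; others in the source may bear on it.

Compound 1 `N#Cc1ccc(OCc2ccsc2)cc1OC(C(=O)O)c1ccccc1Cl` stands lowest of the two numbers in an assay on A10 cells for antagonist activity at Endothelin-1 receptor (Rattus norvegicus) (on this read-out lower numbers stand for stronger inhibition and higher numbers for weaker inhibition), giving 17 nM. Compound 2 `COc1ccccc1C(Oc1cc(OCc2ccsc2)ccc1C#N)C(=O)O` gives 529 nM in this assay, a step of a 31-fold higher number from compound 1 to compound 2 (1.49 log units; beyond the scatter) brought about by methoxy in place of chloro on an aromatic carbon. Compound 3 `N#Cc1ccc(OCc2ccsc2)cc1OC(C(=O)O)c1ccsc1` differs from compound 1 by thiophen-3-yl in place of 2-chlorophenyl on a saturated chain carbon bound to a carbonyl carbon and an oxygen on an aromatic ring. Going by the values given here, no measured step touches this exact change; the one step on record, a 31-fold higher number from compound 1 to compound 2 (1.49 log units; beyond the scatter), alters the same ring by a different group and so bears only loosely on it. For compound 3 the expected step is a 5.9-fold higher number from compound 1 to compound 3 (0.77 log units; beyond the scatter), a rise of middling size. Compound 3 is estimated at 100 nM, within 25 nM to 400 nM.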

Compound 3, half-maximal inhibitory concentration: 630 nM
The estimate for compound 3 lay 6.3-fold (0.80 log units) below the measured number; the measured number lies above the stated range.
By their numbers in this assay, from the lowest: compound 1; then compounds 2 and 3 (each within the scatter of the next).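

At the saturated chain carbon bound to a carbonyl carbon and an oxygen on an aromatic ring, thiophen-3-yl in place of 2-chlorophenyl gives a 37-fold higher number from compound 1 to compound 3 (1.57 log units; beyond the scatter) in this assay, so a second replacement of the 2-chlorophenyl also sharply weakens inhibition. Set against 2-methoxyphenyl, thiophen-3-yl gives a 1.2-fold higher number from compound 2 to compound 3 (0.08 log units; within the scatter), so these two replacements cannot be told apart and only compound 1 stands out. Nothing on hand explains this result.

Open, as far as these compounds go, is whether the chloro itself is what matters: a bromo or methyl group in its place, or an unsubstituted phenyl, would test this.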